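Carbamate in place of acyl on the shared core

This account rests on a few compounds, and the source may have more. Where it says the series, first, only, none or still open, it means among the compounds named here.

In a functional assay on WI-38 VA13 cells (Homo sapiens) for cytotoxicity (on this read-out higher numbers stand for an effect only at larger amounts of compound and lower numbers for an effect already at smaller amounts), compound 3 `CCCC(C)C(=O)Nc1ccc2nc(NC(=O)C3CCCCC3)sc2c1` gives 0.14 ug/mL, the lowest of the two numbers shown. Compound 1 `N#Cc1cccc(C(=O)Nc2ccc3nc(NC(=O)C4CCCCC4)sc3c2)c1` gives 0.52 ug/mL in this assay. Compound 2 `O=C(Nc1ccc2nc(NC(=O)C3CCCCC3)sc2c1)c1ccc(Br)cc1` reaches only the limit > 4 ug/mL in this assay. The step of a 3.7-fold lower number from compound 1 to compound 3 (0.57 log units; beyond the scatter) was modest and the step of an at least 28-fold lower number from compound 2 to compound 3 (1.45 log units; beyond the scatter) large; both swap an aryl group for 1-methylbutyl on a carbonyl carbon. The move to compound 4 `CC(C)COC(=O)Nc1ccc2nc(NC(=O)C3CCCCC3)sc2c1` is isobutoxy in place of 1-methylbutyl on a carbonyl carbon. Among the compounds with values here, no measured step covers an alkoxy group at this position; the nearest comparisons, alkyl against aryl, favour the alkyl chain of compound 3. A small rise is expected, a 2.1-fold higher number from compound 3 to compound 4 (0.33 log units; beyond the scatter), within or close to the scatter. Compound 4 is expected at 0.3 ug/mL, between 0.08 ug/mL and 1.2 ug/mL.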

Compound 4, half-maximal effective concentration: 0.72 ug/mL
For compound 4 the middle estimate is 2.4-fold (0.38 log units) below the measured one; measured number inside the range.
By their numbers in this assay, from the lowest: compound 3; then compounds 1 and 4 (each within the scatter of the next). At a limit, above all of these: compound 2.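

In this assay isobutoxy does not hold the level of 1-methylbutyl on this carbonyl carbon, with a 5.1-fold higher number from compound 3 to compound 4 (0.71 log units; beyond the scatter) as the step. Among the aryl comparisons, a 1.4-fold higher number from compound 1 to compound 4 (0.14 log units; within the scatter) leaves isobutoxy and 3-cyanophenyl not told apart, while an at least 5.5-fold lower number from compound 2 to compound 4 (0.74 log units; beyond the scatter) separates isobutoxy from 4-bromophenyl. The value of compound 2 in that step is a limit: the limit of > 4 ug/mL in this assay, at which 1 of the 4 values shown sits.

Still open, as far as these compounds go, is whether the rise follows the oxygen or the shape of the chain, since 1-methylbutyl and isobutoxy differ in both. A 1-methylbutoxy group or a longer straight alkoxy chain on the same carbonyl carbon would separate the two.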